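Carbamate chain lengthening and half-life in the series

A few compounds are considered here, and "the series" means these few. Any claim that something is new, unique, unknown or untested is made for them only; others in the source may bear on it.

Measured so far:
compound 1, `CCCCCCCNC(=O)Oc1ccc(Cl)cc1C(=O)Nc1ccc(Cl)cc1`, 43 h
compound 2, `CCCCCCCCCNC(=O)Oc1ccc(Cl)cc1C(=O)Nc1ccc(Cl)cc1`, 43 h
compound 3, `CCCNC(=O)Oc1ccc(Cl)cc1C(=O)Nc1ccc(Cl)c(Cl)c1`, 43 h

All three values come from an ADME assay for metabolic stability, read by HPLC, at pH 7.4; on this read-out lower numbers stand for a shorter-lived compound and higher numbers for a longer-lived compound. Compound 1 and compound 2 differ by ethyl in place of hydrogen on a saturated chain carbon, seven bonds along the chain from an amide-type nitrogen, and the step of no change at the digits printed from compound 1 to compound 2 (within the scatter). Compound 3 sits level with compound 1 and compound 2; its core and the core of compound 1 differ in a way that is not broken down here, and the values alone show no gap among the three.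

Compound 4, `CCCCCNC(=O)Oc1ccc(Cl)cc1C(=O)Nc1ccc(Cl)c(Cl)c1`, is not yet measured. It differs from compound 3 by ethyl in place of hydrogen on a saturated chain carbon, three bonds along the chain from an amide-type nitrogen. The two ethyl entries are the same kind of change but not the same: in the first pair the entering ethyl sits seven bonds along the chain from an amide-type nitrogen, here it sits three bonds along. The step from compound 3 to compound 4 is expected to be no change at the digits printed from compound 3 to compound 4 (within the scatter), because no change at the digits printed from compound 1 to compound 2 (within the scatter) showed the same kind of change leaving the half-life where it stood. Compound 4 is therefore estimated at 43 h, between 25 h and 75 h.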

Compound 4, half-life: 43 h
Compound 4: middle estimate and measured number agree at the digits printed; the measured number falls inside the stated range.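

In this assay the new step reads no change at the digits printed from compound 3 to compound 4 (within the scatter), and it sits level with the earlier step on the other core: the same change on two cores in this assay, no change at the digits printed (within the scatter) from compound 1 to compound 2 and no change at the digits printed (within the scatter) from compound 3 to compound 4, 1.0-fold (0.00 log units) apart, within the scatter of two such steps. Within these two pairs, ethyl in place of hydrogen on a saturated chain carbon therefore carries from the core of compound 1 to the core of compound 3 with no readable difference between the steps, whether it enters seven bonds or three bonds along the chain from an amide-type nitrogen. This rests on a single pair per core and shows neither why the half-life stays level nor that the same holds on any other core or at any other place on the chain.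

On these data alone, a branched chain, a chain ending in an amine or a carboxylic acid, and a ring on the carbamate nitrogen remain open. Also open, as far as these compounds go, is how the step reads on a core carrying a nitrile or a methoxy group in place of chlorine.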